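Furan for thiophene on the shared core

The compounds below may be only part of what the source reports. "The series", "measured", "known", "first", "only" and "open" are said of these compounds alone.

Measured so far:
Compound 1, `Oc1cccc(-c2cc(-c3ccsc3)cc(-c3ccccc3O)n2)c1`: in a functional assay on HeLa cells (Homo sapiens) for cytotoxicity, read by CCK-8 assay (a higher number here means a weaker inhibitor, a lower number a stronger inhibitor), compound 1 gives > 50000 nM.
Compound 2, `Oc1ccc(-c2cc(-c3ccsc3)cc(-c3cccc(O)c3)n2)cc1`: in this assay compound 2 gives 2580 nM.
Not yet measured: compound 3, `Oc1cccc(-c2cc(-c3ccoc3)cc(-c3ccccc3O)n2)c1`.

Compound 1 stands at the edge of what this assay reports: its value is a limit and not a number (the limit of > 50000 nM in this assay, at which 1 of the 2 values shown sits). Among the compounds with values here, the only measured step, an at least 19-fold lower number from compound 1 to compound 2 (1.28 log units; beyond the scatter), concerns the hydroxyphenyl groups and leaves the thiophen-3-yl untouched, so it does not bear on the change examined here. Compound 3 differs from compound 1 by furan-3-yl in place of thiophen-3-yl on an aromatic carbon. Within the data shown here, with no measured step on this change, no movement beyond the scatter is expected in this assay. Compound 3 is therefore expected to sit at the limit as well, and the expected step of a number no higher from compound 1 to compound 3 (the limit leaves the size open) is none beyond the scatter. Compound 3 is estimated at 50000 nM, between 20000 nM and 150000 nM.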

Compound 3, half-maximal inhibitory concentration: > 50000 nM
Compound 3: a limit, no number; the forecaster's own chance of this, stated with the estimate: 75%; the middle value sits exactly at the limit.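

In this assay compound 3 gives > 50000 nM, a limit and not a number. Within the data shown here, with compound 1 also at a limit, no step from compound 1 to compound 3 can be read. The compounds shown leave open whether furan-3-yl in place of thiophen-3-yl changes the number at all in this assay.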